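A few compounds are considered here, and "the series" means these few. Any claim that something is new, unique, unknown or untested is made for them only; others in the source may bear on it.

Measured in a functional assay on U-937 cells (Homo sapiens) for antiproliferative activity, with a stated time of 48 h; on this read-out higher numbers stand for an effect only at larger amounts of compound and lower numbers for an effect already at smaller amounts:

- compound 1 `Nc1ccc(NC(=O)CCCCCCC(=O)NO)cc1`: 6400 nM
- compound 2 `O=C(CCCCCCC(=O)Nc1ccc(O)cc1)NO`: 6400 nM
- compound 3 `O=C(CCCCCCC(=O)Nc1cccc(F)c1)NO`: 500 nM

Among these three, compound 3 has the lowest number, at 500 nM, and its gap to each of the other two lies beyond the scatter of this assay. The next compound, compound 4 `O=C(CCCCCCC(=O)Nc1cccc(C(F)(F)F)c1)NO`, differs from it by trifluoromethyl in place of fluoro on an aromatic carbon. For the measured compounds named here, no measured step covers this exchange. The only one available, no change at the digits printed from compound 1 to compound 2 (within the scatter), is hydroxy in place of amino on an aromatic carbon, so it bears only indirectly, showing that one exchange of this kind left the number unmoved. With so little guidance, the expectation stays anchored on compound 3 at 500 nM, with a slight upward allowance and a wide margin on both sides. The estimated change is a 1.3-fold higher number from compound 3 to compound 4 (0.11 log units; within the scatter), which is not expected to go beyond the scatter. For compound 4 the estimated value is 650 nM, with an expected range from 220 nM to 2000 nM.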

Compound 4, half-maximal effective concentration: 1200 nM
The estimate for compound 4 lay 1.8-fold (0.27 log units) below the measured number, and the stated range covers the measured number.
By their numbers in this assay, from the lowest: compound 3; then compound 4; then compounds 1 and 2 (each within the scatter of the next).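

In this assay, for the compounds shown here, this is the first measured exchange at the aromatic carbon meta to a large group: going from fluoro, with 1 heavy atom, to trifluoromethyl, with 4 heavy atoms, gives a 2.4-fold higher number from compound 3 to compound 4 (0.38 log units; beyond the scatter), a modest step that lies just beyond the scatter. The position therefore responds to this exchange, though only slightly, and neither group carries a hydrogen-bond donor or acceptor by the count. Nothing available explains why the number rises with this change.

The compounds shown leave open whether chloro, methyl or methoxy at this position would fall with fluoro or with trifluoromethyl, or whether a bare ring hydrogen would differ from both. They also leave open whether trifluoromethyl would give a similar step at another ring position or with a longer chain.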